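Shifting the chlorine on the amide-bound phenyl ring

A few compounds are considered here, and "the series" means these few. Any claim that something is new, unique, unknown or untested is made for them only; others in the source may bear on it.

Compound 1 `O=C(CSc1nc(Nc2ccccc2)c2ccccc2n1)Nc1ccccc1F`: 9350 nM
Compound 2 `O=C(CSc1nc(Nc2ccccc2)c2ccccc2n1)Nc1cccc(Cl)c1`: 8460 nM
Compound 3 `O=C(CSc1nc(Nc2ccccc2)c2ccccc2n1)Nc1ccc(F)cc1`: 16500 nM

Three compounds sharing one core were measured in a functional assay on NCI-H1975 cells (Homo sapiens) for inhibition, read by MTT assay, with a stated time of 72 h (a higher number here means a weaker inhibitor, a lower number a stronger inhibitor), differing only in the aryl group on the amide-type nitrogen. Compound 2 stands alongside the other two rather than apart from them: the step of a 1.1-fold lower number from compound 1 to compound 2 (0.04 log units; within the scatter) and the step of a 2.0-fold higher number from compound 2 to compound 3 (0.29 log units; within the scatter) are both within the scatter, as is a 1.8-fold higher number from compound 1 to compound 3 (0.25 log units; within the scatter). Compound 4 `O=C(CSc1nc(Nc2ccccc2)c2ccccc2n1)Nc1ccc(Cl)cc1` is the next member, and it differs from compound 2 by 4-chlorophenyl in place of 3-chlorophenyl on an amide-type nitrogen. Among the compounds with values here, no measured step moves a chlorine between these two positions; the nearest guide is the step of a 2.0-fold higher number from compound 2 to compound 3 (0.29 log units; within the scatter), which also ends at a ring substituted in the 4-position, together with a 1.8-fold higher number from compound 1 to compound 3 (0.25 log units; within the scatter), both pointing weakly toward a higher number in this assay without leaving the scatter. Compound 4 is therefore expected to give a step of about a 1.3-fold higher number from compound 2 to compound 4 (0.11 log units; within the scatter), and its estimated value in this assay is 11000 nM, with a range from 5000 nM to 25000 nM.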

Compound 4, half-maximal inhibitory concentration: 8040 nM
Compound 4: middle estimate off by 1.4-fold (0.14 log units), on the high side; the range from low to high includes it.
By their numbers in this assay, from the lowest: compounds 4, 2, 1 and 3 (each within the scatter of the next, the first and the last beyond it).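

In this assay, the 4-chlorophenyl group can take the place of 3-chlorophenyl on the amide-type nitrogen with no readable effect, as a 1.1-fold lower number from compound 2 to compound 4 (0.02 log units; within the scatter) stays within the scatter. Chloro in place of fluoro on an aromatic carbon gives a 2.1-fold lower number from compound 3 to compound 4 (0.31 log units; beyond the scatter) and is the first step in this set to pass beyond the scatter, though only modestly, while a 1.2-fold lower number from compound 1 to compound 4 (0.07 log units; within the scatter) remains within it. Nothing shown here explains why the chloro and fluoro compounds differ.

Going by these compounds, all four aryl groups carry a single halogen, so the effect of a methoxy group, an amine or a carboxylic acid on that ring remains open. The phenyl group on the other nitrogen of the shared core is also constant, which leaves the effect of any change there unknown.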